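A few compounds are considered here, and "the series" means these few. Any claim that something is new, unique, unknown or untested is made for them only; others in the source may bear on it.

Going by the values given here, in a functional assay on M14 cells (Homo sapiens) for cytotoxicity (a higher number here means a weaker inhibitor of growth, a lower number a stronger inhibitor of growth), compound 1 `CSc1ccc(C2=C(c3ccc(C)c(C)c3)C(=O)N3CCCC3C2)cc1` gives 800 nM, the second highest of three numbers so far. Compound 2 `COc1ccc(C2=C(c3ccc(SC)cc3)CC3CCCN3C2=O)cc1OC` sits higher at 5000 nM, and compound 3 `CSc1ccc(C2=C(c3ccc(OCC4CO4)cc3)C(=O)N3CCCC3C2)cc1` sits lower at 90 nM, both beyond the scatter from compound 1. Compound 4 `CSc1ccc(C2=C(c3ccc(Br)cc3)C(=O)N3CCCC3C2)cc1` has not yet been measured. It has 4-bromophenyl in place of 3,4-dimethylphenyl on a double-bonded ring carbon. Among the compounds with values here, no measured pair shows this change directly, so any forecast is uncertain. Still, compound 3 at 90 nM shows that much lower numbers occur in this small set. In this assay, a small step toward a lower number, about the size of the scatter, is expected a 2.0-fold lower number from compound 1 to compound 4 (0.30 log units; within the scatter). For compound 4 the estimated value is 400 nM, with an expected range of 100 nM to 1500 nM.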

Compound 4, concentration for 50% growth inhibition: 9000 nM
Estimate against measurement, compound 4: 23-fold (1.35 log units) below; the whole stated range lies below it.
By their numbers in this assay, from the lowest: compound 3; then compound 1; then compounds 2 and 4 (each within the scatter of the next).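

In this assay, the group on this double-bonded ring carbon matters a great deal: 4-bromophenyl in place of 3,4-dimethylphenyl gives an 11-fold higher number from compound 1 to compound 4 (1.05 log units; beyond the scatter), although the two groups have the same ring and nearly the same size by atom count. Bromo in place of (oxiran-2-yl)methoxy on the aromatic carbon gives a 100-fold higher number from compound 3 to compound 4 (2.00 log units; beyond the scatter), the widest step seen so far. Nothing available here bears on the reason for either step. Still open, from the compounds shown here alone, is whether a propoxy chain or an amine on that aromatic carbon would come close to compound 3 at 90 nM, which would show whether the oxirane ring itself is needed.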